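Cytotoxicity notes on an imine series: compound 4

The source may hold more compounds than are shown below. What is called first, only, known or untested is meant among the compounds shown, and "the series" means these compounds.

Measured compounds in an ADME assay on cells (Rhabdomyosarcoma cell, Homo sapiens) for cytotoxicity, read by MTT assay, with a stated time of 72 h; a lower number here means that less compound is tolerated, a higher number that more compound is tolerated:
compound 1 `Clc1ccc(/C=N/c2sc3c(c2-c2nc4ccccc4s2)CCCC3)c(Cl)c1`: 56.6 ug/mL
compound 2 `O=[N+]([O-])c1ccc(/C=N/c2sc3c(c2-c2nc4ccccc4s2)CCCC3)cc1`: 316 ug/mL
compound 3 `C(=C/c1ccccc1)\C=N\c1sc2c(c1-c1nc3ccccc3s1)CCCC2`: 207 ug/mL

Compound 3 stands second highest of the three numbers. Its nearest neighbour is compound 2, and that pair, a 1.5-fold lower number from compound 2 to compound 3 (0.18 log units; within the scatter), lies within the scatter, so no order between compound 2 and compound 3 is claimed. The step of a 3.7-fold higher number from compound 1 to compound 3 (0.56 log units; beyond the scatter) is beyond the scatter, as is a 5.6-fold higher number from compound 1 to compound 2 (0.75 log units; beyond the scatter); compound 1 is therefore the one of the three that is tolerated least.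

Compound 4 `Clc1ccc2sc(-c3c(/N=C/C=C/c4ccccc4)sc4c3CCCC4)nc2c1` differs from compound 3 in one place: chloro in place of hydrogen on an aromatic carbon. The change sits on the shared core, not on the carbon with a double bond to nitrogen where all three measured steps were made. For the measured compounds named here, none of the measured steps therefore bears directly on this change; they only show that the series moves within a modest span when the imine substituent is varied, and give no guidance for a chloro on the core.

Going by the values given here, with no step bearing on the change, compound 4 is expected to sit close to compound 3, with the step of a 1.0-fold higher number from compound 3 to compound 4 (0.01 log units; within the scatter) expected to fall within the scatter. The estimate for compound 4 in this assay is 210 ug/mL, with a range from 90 ug/mL to 480 ug/mL.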

Compound 4, half-maximal cytotoxic concentration: 212 ug/mL
The estimate for compound 4 lay 1.0-fold (0.00 log units) below the measured number; the range from low to high includes it.
By their numbers in this assay, from the lowest: compound 1; then compounds 3, 4 and 2 (each within the scatter of the next).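

In this assay, the only change on the shared core among the steps shown gives a 1.0-fold higher number from compound 3 to compound 4 (0.01 log units; within the scatter), so chloro in place of hydrogen on this aromatic carbon, meta to a fused ring and para to a fused ring, stays within the scatter. With 2-phenylethenyl held on the carbon with a double bond to nitrogen, this position therefore accepts chloro without a step beyond the scatter, whereas changes at that carbon gave a 5.6-fold higher number from compound 1 to compound 2 (0.75 log units; beyond the scatter) and a 3.7-fold higher number from compound 1 to compound 3 (0.56 log units; beyond the scatter). Nothing available explains why the number holds at this position.

The compounds shown carry chloro on this aromatic carbon only together with 2-phenylethenyl, so it remains open whether the same holds with 4-nitrophenyl or 2,4-dichlorophenyl on the carbon with a double bond to nitrogen. On these data alone, it also remains open whether an amine, a carboxylic acid or a methoxy group at this position would stay as close to compound 3 as chloro does.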